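A few compounds are considered here, and "the series" means these few. Any claim that something is new, unique, unknown or untested is made for them only; others in the source may bear on it.

Measured so far in an ADME assay for permeability, using PAMPA, with a stated time of 30 min, at pH 7.4; a higher number here means that the compound crosses the layer faster, a lower number that the compound crosses the layer more slowly:
compound 1, `COc1ccc(F)cc1CNCCCNc1ccnc2cc(Oc3ccc(F)cc3)ccc12`: 317 10^-6 cm/s
compound 2, `COc1cccc(Oc2ccc3c(NCCCNCc4cc(F)ccc4OC)ccnc3c2)c1`: 317 10^-6 cm/s
compound 3, `COc1ccc(-c2ccc3c(NCCCNCc4cc(F)ccc4OC)ccnc3c2)cc1`: 237 10^-6 cm/s

Compound 3 sits within the scatter of both of its neighbours: a 1.3-fold lower number from compound 1 to compound 3 (0.13 log units; within the scatter) and a 1.3-fold lower number from compound 2 to compound 3 (0.13 log units; within the scatter). Between the other two, no change at the digits printed from compound 1 to compound 2 (within the scatter). None of the three steps reaches beyond the scatter, so the three numbers read as a single level in this assay rather than as a spread.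

Compound 4, `COc1ccc(F)cc1CNCCCNc1ccnc2cc(Oc3ccccc3OC)ccc12`, is not yet measured. It differs from compound 3 in one place:
2-methoxyphenoxy in place of 4-methoxyphenyl on an aromatic carbon

Within the data shown here, two measured steps bear on this change. Both put a methoxyphenyl in place of a phenoxy group on an aromatic carbon, which is the present change run in the opposite sense: a 1.3-fold lower number from compound 1 to compound 3 (0.13 log units; within the scatter) and a 1.3-fold lower number from compound 2 to compound 3 (0.13 log units; within the scatter). The step of no change at the digits printed from compound 1 to compound 2 (within the scatter) further shows that exchanging one aryloxy group for another on that carbon left the number where it was. Taken together, a small move upward from compound 3 is expected, not one beyond the scatter: the estimated step is a 1.3-fold higher number from compound 3 to compound 4 (0.10 log units; within the scatter). For compound 4 in this assay the expected value is 300 10^-6 cm/s, with a range from 200 10^-6 cm/s to 450 10^-6 cm/s.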

Compound 4, apparent permeability: 317 10^-6 cm/s
Beside the measured number, compound 4's estimate is 1.1-fold (0.02 log units) below it; the range from low to high includes it.
By their numbers in this assay, from the lowest: compounds 3, 1, 2 and 4 (each within the scatter of the next).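

In this assay, the 2-methoxyphenoxy group on this aromatic carbon stays at the level of the groups already seen there (a 1.3-fold higher number from compound 3 to compound 4 (0.13 log units; within the scatter)). Against the two other aryloxy groups, the 2-methoxyphenyl on the oxygen gives the same printed number (no change at the digits printed from compound 2 to compound 4 (within the scatter)) and (no change at the digits printed from compound 1 to compound 4 (within the scatter)). Compound 4 thus extends the flat reading to a third aryloxy group, and the methoxy group on the phenoxy ring, in its 2-methoxy or 3-methoxy form, leaves the number where the 4-fluorophenoxy group has it, while the four compounds still read as a single level. No supporting observation at hand accounts for this flat behaviour.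

Still open, going by these compounds, is whether this level holds once the aromatic ring on this carbon gives way to an amine or a carboxylic acid, or once a longer chain stands between that ring and the core. The compounds shown speak only to this one carbon, so the effect of any change elsewhere on the shared core, or on the fluorinated methoxybenzyl end, remains open.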